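Replacing the Hydroxy Group of Compound 3 with Isopropoxymethyl

The compounds below may be only part of what the source reports. "The series", "measured", "known", "first", "only" and "open" are said of these compounds alone.

Of the compounds shown here, three have been measured in a functional assay on HEK293 cells with D(4) dopamine receptor (Homo sapiens) as the target, read by FLIPR; on this read-out higher numbers stand for an effect only at larger amounts of compound and lower numbers for an effect already at smaller amounts. Compound 1 `Cc1cc(C)cc(/C(CCN2CCN(c3ccccn3)CC2)=N/O)c1` gives 45.8 nM, and compound 2 `CO/N=C(\c1ccc(Cl)cc1)C(O)CN1CCN(c2ccccn2)CC1` gives 46 nM. Compound 3 `CO/N=C(/c1ccc(Cl)cc1)C(O)CN1CCN(c2ccccn2)CC1` gives 22.6 nM, the lowest of the three numbers; its nearest neighbour is compound 1, and both compound 1 and compound 2 lie beyond the scatter from it, so compound 3 is the most potent of the three. Within the data shown here, the only step between compounds that differ in one place is a 2.0-fold lower number from compound 2 to compound 3 (0.31 log units; beyond the scatter), and the fact that one of compounds 2 and 3 is drawn with a defined configuration and the other without, at the place where they differ is the sole evidence that bears on it.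

Compound 4 `CO/N=C(/c1ccc(Cl)cc1)C(COC(C)C)CN1CCN(c2ccccn2)CC1` differs from compound 3 by isopropoxymethyl in place of hydroxy on a saturated chain carbon bound to a carbon with a double bond to nitrogen and a saturated chain carbon. Among the measured compounds shown here, no measured step touches this position; the one step on record concerns a stereo element elsewhere in the molecule, so nothing in the present numbers speaks for a change beyond the scatter in this assay . Compound 4 is therefore expected to show a 1.3-fold higher number from compound 3 to compound 4 (0.12 log units; within the scatter), and its value is estimated at 30 nM, with a range from 8 nM to 110 nM.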

Compound 4, half-maximal effective concentration: 3210 nM
Compound 4: middle estimate off by 110-fold (2.03 log units), on the low side; measured number outside the range, above it.
By their numbers in this assay, from the lowest: compound 3; then compounds 1 and 2 (each within the scatter of the next); then compound 4.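

Among these compounds, the position on the saturated chain carbon bound to a carbon with a double bond to nitrogen proves far from indifferent in this assay: isopropoxymethyl in place of hydroxy gives a 140-fold higher number from compound 3 to compound 4 (2.15 log units; beyond the scatter), a much larger change than the only earlier step, a 2.0-fold lower number from compound 2 to compound 3 (0.31 log units; beyond the scatter). The exchange removes the hydrogen-bond donor of hydroxy and brings in 5 heavy atoms where there was 1, and this single step cannot separate those two differences. Nothing on record bears on the origin of this loss, since the only available observation concerns a stereo element elsewhere in the molecule.

As far as these compounds go, it remains open whether methoxy, hydroxymethyl or an amine at this place would stay close to compound 3. From the compounds shown here alone, it is also open whether isopropoxymethyl would have the same effect with the double bond drawn E, as in compound 2.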